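This account rests on a few compounds, and the source may have more. Where it says the series, first, only, none or still open, it means among the compounds named here.

Measured in a functional assay on CHO cells for antagonist activity at C-C chemokine receptor type 4 (Homo sapiens), read by radioligand binding and GTPgammaS binding; a higher number here means a weaker inhibitor, a lower number a stronger inhibitor:
compound 1 `COc1cccc2c1c(NS(=O)(=O)c1cccc(Cl)c1Cl)nn2C` gives 603 nM;
compound 2 `COc1cc2c(cc1NS(=O)(=O)c1cccc(Cl)c1Cl)[nH]c(=O)n2CC(N)=O` gives 457 nM;
compound 3 `COc1cc2c(cc1NS(=O)(=O)c1cccc(Cl)c1Cl)[nH]c(=O)n2C(C)C` gives 1000 nM.

Compound 3 carries the highest number of the three; its gap to compound 1 lies within the scatter, its gap to compound 2 beyond it. Compound 4 `COc1cc2c(cc1NS(=O)(=O)c1cccc(Cl)c1Cl)[nH]c(=O)n2CCN(C)C` differs from compound 3 by 2-(dimethylamino)ethyl in place of isopropyl on an aromatic nitrogen. Among the compounds with values here, the only measured step at this aromatic nitrogen is a 2.2-fold higher number from compound 2 to compound 3 (0.34 log units; beyond the scatter), which moved from a chain bearing a nitrogen to isopropyl. Compound 4 moves back from isopropyl to a chain bearing a nitrogen, so a step of similar size in the opposite direction is expected in this assay. For compound 4 the expected step is a 2.0-fold lower number from compound 3 to compound 4 (0.30 log units; within the scatter). Compound 4 is therefore estimated at 500 nM, between 200 nM and 1500 nM.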

Compound 4, half-maximal inhibitory concentration: 2000 nM
Beside the measured number, compound 4's estimate is 4.0-fold (0.60 log units) below it; the measured number lies above the stated range.
By their numbers in this assay, from the lowest: compounds 2, 1, 3 and 4 (each within the scatter of the next, the first and the last beyond it).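

In this assay, a nitrogen in the chain on the aromatic nitrogen does not by itself bring the number down: 2-(dimethylamino)ethyl in place of isopropyl gives a 2.0-fold higher number from compound 3 to compound 4 (0.30 log units; within the scatter). The two nitrogen-bearing chains are not interchangeable here, since (dimethylamino)methyl in place of carbamoyl on the saturated chain carbon gives a 4.4-fold higher number from compound 2 to compound 4 (0.64 log units; beyond the scatter).

As far as these compounds go, whether this gap belongs to the carbamoyl group itself stays open; an N-methyl amide, a carboxylic acid or a longer chain ending in carbamoyl would test it. Nothing measured on these chains accounts for the gap.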